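Clearance in a small series: a second methyl on the chain

The compounds below may be only part of what the source reports. "The series", "measured", "known", "first", "only" and "open" are said of these compounds alone.

Compound 1, `O=C(CCCCCNc1c(Nc2ccccc2)c(=O)c1=O)NO`, gives a limit of < 4.8 uL/min in an ADME assay on cells (Hepatocyte, Homo sapiens) for pharmacokinetics, read by LC-MS, with a stated time of 90 min, tested at 1 uM; a lower number here means slower removal, a higher number faster removal of the compound.
Compound 2, `CC(CCCCC(=O)NO)Nc1c(Nc2ccccc2)c(=O)c1=O`, gives a limit of < 5 uL/min in this assay.
Compound 3, `CC(CCCCC(=O)NO)Nc1c(Nc2ccc(C(F)(F)F)cc2)c(=O)c1=O`, gives 21 uL/min in this assay.

Compound 1 and compound 2 each return only a limit, not a number, so the change from compound 1 to compound 2, (methyl in place of hydrogen on a saturated chain carbon bound to a nitrogen on an aromatic ring and a saturated chain carbon), shows a step that the two limits leave unreadable from compound 1 to compound 2. The change from compound 2 to compound 3 shows an at least 4.2-fold higher number from compound 2 to compound 3 (0.62 log units; beyond the scatter). The difference between the cores of compound 1 and compound 3 is not broken down here.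

Compound 4, `CC(C)(CCCCC(=O)NO)Nc1c(Nc2ccc(C(F)(F)F)cc2)c(=O)c1=O`, differs from compound 3 by methyl in place of hydrogen on a saturated chain carbon bound to a nitrogen on an aromatic ring and two saturated chain carbons. The place is bound to two saturated chain carbons rather than one, so this is the same kind of change as before, not the same change. For compound 4 the step of a 1.5-fold lower number from compound 3 to compound 4 (0.18 log units; within the scatter) is expected, resting on compound 3 at 21 uL/min and on the earlier methyl step being unreadable. Compound 4 is estimated at 14 uL/min, between 6 uL/min and 35 uL/min.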

Compound 4, intrinsic clearance in a liver preparation (reported as CLH), per the amount of preparation that the assay uses: 29 uL/min
For compound 4 the middle estimate is 2.1-fold (0.32 log units) below the measured one; measured number inside the range.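

In this assay the second methyl gives a 1.4-fold higher number from compound 3 to compound 4 (0.14 log units; within the scatter), so on the core of compound 3 this change leaves the clearance reading no different from repeat measurements. The earlier methyl step cannot be read, as compound 1 and compound 2 each return only a limit, and it sits at a carbon bound to one saturated chain carbon rather than two, so nothing here shows that the change behaves alike on both cores. No measured property shown here accounts for the result.

From the compounds shown here alone, what an ethyl group or a longer chain at this place would do remains open. So does the effect of the second methyl on the core of compound 2.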